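A Halogen Swap on the Pendant Phenyl Ring

The source may report more compounds than this note shows. Statements on the series, on what has been measured and on what is new or still open speak of the compounds shown alone.

This study concerns a family of compounds that share a common core and differ in the group attached to one aromatic carbon. Compound 1 `CCn1cc(-c2nc3ccc([N+](=O)[O-])cc3o2)c(=O)c2cc(F)c(N3CCNC(C)C3)c(F)c21` is the strongest inhibitor so far: in a functional assay on BGC-823 cells (Homo sapiens) for antiproliferative activity, read by MTT assay, with a stated time of 48 h (on this read-out higher numbers stand for weaker inhibition and lower numbers for stronger inhibition), compound 1 gives 2740 nM. Compound 2 `CCn1cc(-c2ccccc2)c(=O)c2cc(F)c(N3CCNCC3)cc21` carries a plain phenyl group, and in this assay compound 2 gives 75400 nM. Compound 3 `CCn1cc(-c2ccc(Cl)cc2)c(=O)c2cc(F)c(N3CCNCC3)cc21` carries a 4-chlorophenyl group instead, and in this assay compound 3 gives 14600 nM, which places it second highest of the three numbers. Among the compounds with values here, the only single-change step available is the one a 5.2-fold lower number from compound 2 to compound 3 (0.71 log units; beyond the scatter), showing that adding a chlorine to the phenyl ring brought a real gain.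

Compound 4 `CCn1cc(-c2cccc(F)c2)c(=O)c2cc(F)c(N3CCNCC3)cc21` takes the next step: 3-fluorophenyl in place of 4-chlorophenyl on an aromatic carbon. Within the data shown here, no measured pair tells how a fluorine at this new position compares with a chlorine at the old one, so the expectation rests on the step from compound 2 to compound 3 alone. A halogen stays on the ring, so compound 4 is expected to sit between compound 2 and compound 3, with a modest loss relative to compound 3 of about a 1.7-fold higher number from compound 3 to compound 4 (0.23 log units; within the scatter). For compound 4 the estimated value in this assay is 25000 nM, within a range of 8000 nM to 80000 nM.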

Compound 4, half-maximal inhibitory concentration: 27300 nM
Compound 4: the middle estimate sits 1.1-fold (0.04 log units) below what was measured, and the stated range covers the measured number.
By their numbers in this assay, from the lowest: compound 1; then compounds 3 and 4 (each within the scatter of the next); then compound 2.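

In this assay, a halogen on the pendant phenyl ring brings a gain for the second time (a 2.8-fold lower number from compound 2 to compound 4 (0.44 log units; beyond the scatter)), so the benefit first seen with chlorine (a 5.2-fold lower number from compound 2 to compound 3 (0.71 log units; beyond the scatter)) is not confined to the 4-chlorophenyl group. The swap between the two halogenated rings (a 1.9-fold higher number from compound 3 to compound 4 (0.27 log units; within the scatter)) stays within the usual scatter, so 3-fluorophenyl and 4-chlorophenyl cannot be told apart here, even though the halogen and its location on the ring changed together. Nothing measured here explains why either halogen helps.

Within the data shown here, what remains open is whether the kind of halogen or its location on the ring matters more, since no pair of compounds holds one fixed while the other changes. It is also unknown how a phenyl ring carrying something other than a halogen, such as an amine, a carboxylic acid or a longer chain, would compare with the fluorine and chlorine compounds on the same shared core.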